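The source may report more compounds than this note shows. Statements on the series, on what has been measured and on what is new or still open speak of the compounds shown alone.

Working notes on the series.

Compound 1 `CN(c1ccncc1)n1cccc1` is the starting point. In a functional assay on the whole organism with Mus musculus as the target (a higher number here means that more compound is needed for the effect, a lower number that less compound is needed), compound 1 gives only a limit, > 20 mg/kg, and no number. Compound 2 `CCCN(c1ccncc1)n1cccc1` likewise gives only a limit in this assay, > 20 mg/kg. Compound 3 `CCCCN(c1ccncc1)n1cccc1` gives only a limit as well, > 20 mg/kg. Because all three values sit at the limit of > 20 mg/kg in this assay, at which 3 of the 3 values shown sit, the three measured steps carry no readable size: a step that the two limits leave unreadable from compound 1 to compound 2, a step that the two limits leave unreadable from compound 1 to compound 3 and a step that the two limits leave unreadable from compound 2 to compound 3. Each of them alters the substituent on the saturated chain carbon bound to the nitrogen on the aromatic ring, and none of them touches the five-membered aromatic ring.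

Compound 4 `CC(O)c1cccn1N(C)c1ccncc1` is not yet measured in this assay. Its change from compound 1 is 1-hydroxyethyl in place of hydrogen on an aromatic carbon. Among the compounds with values here, no measured step bears on this position, and the three known steps give no size in either direction, so nothing in the measured data argues for a step in this assay larger than the scatter. The expectation for compound 4 is therefore that its value stays near the region where compound 1 sits, with an estimated step that the limit leaves unreadable from compound 1 to compound 4. For compound 4 the expected value in this assay is 30 mg/kg, with a range from 10 mg/kg to 100 mg/kg, and most likely the assay again reports only a limit.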

Compound 4, dose for half-maximal effect: > 20 mg/kg
Compound 4 gave a limit, no number (the forecaster's own chance of this, stated with the estimate: 75%); the middle value is on the limit's open side.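

In this assay compound 4 gives > 20 mg/kg, a limit and no number, so no size can be read for its step against compound 1, and the series stays at one value: the limit of > 20 mg/kg in this assay, at which 4 of the 4 values shown sit.

The compounds shown leave open whether either the chain changes or 1-hydroxyethyl on the aromatic carbon alters the dose needed at all.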